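Hydroxy and methoxy exchange on the benzylidene-type aryl group

A few compounds are considered here, and "the series" means these few. Any claim that something is new, unique, unknown or untested is made for them only; others in the source may bear on it.

Title aside, the values below come from a functional assay on A549 cells (Homo sapiens) for antiproliferative activity, read by sulforhodamine B assay, with a stated time of 48 h; on this read-out lower numbers stand for stronger inhibition and higher numbers for weaker inhibition:
- compound 1 `COc1cccc(/C=C/C(=O)C(=Cc2ccc(O)c(F)c2)C(=O)/C=C/c2cccc(OC)c2OC)c1OC`: 200 nM
- compound 2 `COc1ccc(/C=C/C(=O)C(=Cc2ccc(O)c(OC)c2)C(=O)/C=C/c2ccc(OC)cc2OC)c(OC)c1`: 590 nM

Of these two compounds, compound 2 has the higher number at 590 nM, so it shows the weaker inhibition, and its gap to compound 1 lies beyond the scatter. The two differ in more than one place, so their gap does not isolate any single structural change.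

The next compound is compound 3 `COc1ccc(/C=C/C(=O)C(=Cc2ccc(OC)c(O)c2)C(=O)/C=C/c2ccc(OC)cc2OC)c(OC)c1`. It keeps the rest of compound 2 and carries 3-hydroxy-4-methoxyphenyl in place of 4-hydroxy-3-methoxyphenyl on a double-bonded chain carbon bound to a double-bonded chain carbon. For the measured compounds named here, the two structures have the same atoms, joined differently, and no measured pair tests this exchange. Only a small shift towards stronger inhibition is therefore expected, one that stays within the scatter, and the anchor is compound 2 at 590 nM. The expected change is a 1.3-fold lower number from compound 2 to compound 3 (0.12 log units; within the scatter). In this assay, compound 3 is estimated at 450 nM, with an expected range from 150 nM to 1300 nM.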

Compound 3, half-maximal inhibitory concentration: 380 nM
Compound 3: middle estimate off by 1.2-fold (0.07 log units), on the high side; the range from low to high includes it.
By their numbers in this assay, from the lowest: compounds 1, 3 and 2 (each within the scatter of the next, the first and the last beyond it).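

In this assay, 3-hydroxy-4-methoxyphenyl in place of 4-hydroxy-3-methoxyphenyl on a double-bonded chain carbon bound to a double-bonded chain carbon gives a 1.6-fold lower number from compound 2 to compound 3 (0.19 log units; within the scatter). For the compounds shown here, this is the first pair that differs in one place, and it shows that these two arrangements of hydroxy and methoxy on the aryl group cannot be told apart in this read-out, with the rest of compound 2 held fixed. No supporting measurement bears on this step, so nothing can be said about its origin.

The compounds shown leave open whether a free hydroxy group on this aryl group matters at all, a question that 3,4-dimethoxyphenyl or 3-amino-4-methoxyphenyl at the same place would address. Compound 2 and compound 3 each differ from compound 1 in more than one place, so the steps to it cannot be read, and the value of compound 1, 200 nM, cannot be assigned to its fluorine-bearing aryl group or to its other aryl groups.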